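This account rests on a few compounds, and the source may have more. Where it says the series, first, only, none or still open, it means among the compounds named here.

Three ureas share one core and differ only on the aniline ring or in configuration. Compound 1 `CCc1cccc(NC(=O)N[C@@H](C)c2ccccc2)c1` carries an ethyl group there; in an ADME assay on the whole organism with Oryza sativa as the target, tested at 10 uM (a higher number here means a weaker effect of the compound at the concentration tested, a lower number a stronger effect), compound 1 gives 86%. Compound 2 `COc1ccccc1NC(=O)N[C@H](C)c1ccccc1` and compound 3 `COc1ccccc1NC(=O)N[C@@H](C)c1ccccc1` carry a methoxy group instead and are mirror images of each other at the saturated chain carbon; in this assay compound 2 gives 96% and compound 3 gives 95%. For the measured compounds named here, the one step among measured compounds that alters a single feature, a number 1 percentage points lower from compound 2 to compound 3 (within the scatter), rests solely on the fact that (the fact that compounds 2 and 3 differ only in the configuration as drawn). Compound 3 thus lies within the scatter of both compound 2 and compound 1, and the three numbers together show only a weak effect at this concentration.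

Compound 4 `C[C@H](NC(=O)Nc1ccccc1Br)c1ccccc1` differs from compound 3 by bromo in place of methoxy on an aromatic carbon. Going by the values given here, no measured step exchanges one substituent for another, so nothing measured speaks for a shift beyond the scatter, and the one configurational step was small. Compound 4 is therefore expected to give 91% in this assay, between 76% and 100%, a step of a number 4 percentage points lower from compound 3 to compound 4 (within the scatter) that is estimated to stay within the scatter.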

Compound 4, a percentage reported as activity, at one concentration (the size of the read-out at that concentration, not a potency): 102%
Beside the measured number, compound 4's estimate is 11 percentage points below it; the whole stated range lies below it.
By their numbers in this assay, from the lowest: compounds 1, 3, 2 and 4 (each within the scatter of the next, the first and the last beyond it).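

This is the first exchange of one substituent for another among the compounds shown: in this assay, bromo in place of methoxy on an aromatic carbon, ortho to a large group, gives a number 7 percentage points higher from compound 3 to compound 4 (within the scatter). The hydrogen-bond acceptor that methoxy carries leaves with this exchange, yet the read-out of these two compounds does not separate the two groups at this position. What is known about these compounds offers no explanation that bears on this exchange.

Going by these compounds, whether an amine, a carboxylic acid or a longer chain at this place on the ring would move the read-out beyond the scatter remains open. Also open, on these data alone, is whether the mirror image of compound 4 would stay within the scatter of compound 4, as the mirror-image pair carrying methoxy does.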